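A Benzylamino Group Replaces a Selenium-Bearing Chain

The source may report more compounds than this note shows. Statements on the series, on what has been measured and on what is new or still open speak of the compounds shown alone.

Measured so far:
- compound 1 `CCCCC[Se]c1nc([Se]CCCCC)c2ccccc2n1`: > 100000 nM
- compound 2 `CSc1nc(NCCCc2ccccc2)c2ccccc2n1`: 73400 nM

Of the compounds shown here, two have been tested in an ADME assay on BEAS-2B cells (Homo sapiens) for cytotoxicity, read by MTT assay, with a stated time of 72 h; on this read-out lower numbers stand for stronger inhibition of growth and higher numbers for weaker inhibition of growth. In this assay compound 1 gives > 100000 nM, which is a limit of the assay rather than a number. Compound 1 therefore stands at the limit of > 100000 nM in this assay, at which 1 of the 2 values shown sits, so all that is known of it is that its growth inhibition is weak. In this assay compound 2 gives 73400 nM, a weak inhibition as well, and the two results sit close together.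

Compound 3 `CCCCC[Se]c1nc(NCc2ccccc2)c2ccccc2n1` is not yet measured. It differs from compound 1 by a group of 8 heavy atoms (7 carbon, 1 nitrogen; one six-membered aromatic ring of carbon only) in place of a group of 6 heavy atoms (5 carbon, 1 selenium; no ring), on an aromatic carbon. The new group is a benzylamino group, and the chain it replaces has no common name. Among the measured compounds shown here, no measured pair that differs in exactly this way exists, so the size of the step can only be guessed. The step from compound 1 to compound 3 in this assay is expected to be small, not beyond the usual scatter, and the expectation is that compound 3 stays in the same weakly inhibiting region, as an at least 1.1-fold lower number from compound 1 to compound 3 (0.07 log units; that floor lies within the scatter). Compound 3 is estimated at 85000 nM, within 30000 nM to 200000 nM, and a limit-only result is quite possible.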

Compound 3, concentration for 50% growth inhibition: 44100 nM
The estimate for compound 3 lay 1.9-fold (0.28 log units) above the measured number; the range from low to high includes it.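

Among the compounds shown here, the swap at this position, next to the ring nitrogen, is the first change in these compounds whose effect can be read: in this assay, putting a benzylamino group in place of one selenium-bearing chain gives an at least 2.2-fold lower number from compound 1 to compound 3 (0.35 log units; beyond the scatter). Compound 1 and compound 2 differ in more than one place, so they could not show what a change at this position alone does, whereas this pair shows that one selenium-bearing chain can give way to benzylamino with the other left in place, and that the number then drops by more than the scatter, although compound 3, at 44100 nM, is still a weak inhibitor of growth. The true size of the step remains unknown because compound 1 has only a limit, not a number, in this assay: the limit of > 100000 nM in this assay, at which 1 of the 3 values shown sits.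

As far as these compounds go, whether this drop belongs to the benzylamino group itself or would come with any amine stays open, and a butylamino group or a morpholine ring on the same aromatic carbon would separate those two readings. The compounds shown also leave open what the remaining selenium-bearing chain contributes, which a pentylthio chain in its place would address.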